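A few compounds are considered here, and "the series" means these few. Any claim that something is new, unique, unknown or untested is made for them only; others in the source may bear on it.

Compound 1, `Cc1ccc(OCC(=O)N(C)Cc2cccs2)cc1`: 400 nM
Compound 2, `Cc1ccc(OCC(=O)N(Cc2cccs2)c2ccon2)cc1`: 2 nM
Compound 3, `Cc1ccc(OCC(=O)N(Cc2cccs2)c2nccs2)cc1`: 2240 nM

All three were measured in an assay on HEK293 cells for agonist activity at transient receptor potential cation channel subfamily M member 8 (Homo sapiens), read by fluorescence and calcium flux, with a stated time of 15 min; on this read-out lower numbers stand for an effect already at smaller amounts and higher numbers for an effect only at larger amounts of compound. Compound 3 stands highest of the three numbers. Its nearest neighbour is compound 1, with a 5.6-fold higher number from compound 1 to compound 3 (0.75 log units; beyond the scatter), and compound 2 lies furthest away, with a 1100-fold higher number from compound 2 to compound 3 (3.05 log units; beyond the scatter). The third measured step, a 200-fold lower number from compound 1 to compound 2 (2.30 log units; beyond the scatter), shows how strongly the number responds to what sits on this nitrogen.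

Compound 4, `CCC(C)N(Cc1cccs1)C(=O)COc1ccc(C)cc1`, has not been measured. It differs from compound 3 in one place: sec-butyl in place of 1,3-thiazol-2-yl on an amide-type nitrogen. The step that bears most directly on this change is a 5.6-fold higher number from compound 1 to compound 3 (0.75 log units; beyond the scatter), where the 1,3-thiazol-2-yl took the place of a methyl on the same nitrogen and the number rose modestly. The step from compound 3 to compound 4 puts a plain alkyl group back in that position, though sec-butyl rather than methyl, so the nearest reference is compound 1 at 400 nM. The large steps involving compound 2 concern the 1,2-oxazol-3-yl and give no direct guide to an alkyl group. A modest step to a lower number is therefore expected, a 4.5-fold lower number from compound 3 to compound 4 (0.65 log units; beyond the scatter). For compound 4 the estimate is 500 nM, within a range of 100 nM to 2500 nM.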

Compound 4, half-maximal effective concentration: 2000 nM
Compound 4: middle estimate off by 4.0-fold (0.60 log units), on the low side; the measured number falls inside the stated range.
By their numbers in this assay, from the lowest: compound 2; then compound 1; then compounds 4 and 3 (each within the scatter of the next).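

Putting sec-butyl in place of the 1,3-thiazol-2-yl on this amide-type nitrogen leaves the number where it was (a 1.1-fold lower number from compound 3 to compound 4 (0.05 log units; within the scatter)), so here an open carbon chain and a five-membered aromatic ring with two hetero atoms read alike. Among these compounds, the earlier compounds held only one alkyl group at this position, and the new one shows that alkyl groups do not all read alike there, since sec-butyl in place of methyl moves the number modestly (a 5.0-fold higher number from compound 1 to compound 4 (0.70 log units; beyond the scatter)). Compound 2 now stands still further apart from a second group on this nitrogen (a 1000-fold higher number from compound 2 to compound 4 (3.00 log units; beyond the scatter)), so among the four groups shown, the low number belongs to the 1,2-oxazol-3-yl alone, and neither the alkyl groups nor the 1,3-thiazol-2-yl come near it.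

The compounds shown leave open whether a chain of intermediate size such as ethyl, or a longer chain such as n-butyl, would fall with compound 1 or with compound 4, and whether a 1,2-oxazol-3-yl carrying a methyl group would keep the low number of compound 2. Nothing given here offers any independent measurement that accounts for these differences.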